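Changing the aryl group on an aromatic nitrogen

The compounds below may be only part of what the source reports. "The series", "measured", "known", "first", "only" and "open" are said of these compounds alone.

Measured compounds in a functional assay on A549 cells (Homo sapiens) for cytotoxicity, read by MTT assay, with a stated time of 72 h; a lower number here means a stronger inhibitor, a higher number a weaker inhibitor: compound 1 `Cn1c(=O)c(C(=O)Nc2ccc(Oc3ccncc3-c3cccnc3)c(F)c2)nn(-c2ccc(Cl)cc2)c1=O` gives 930 nM; compound 2 `Cn1c(=O)c(C(=O)Nc2ccc(Oc3ccncc3-c3cccnc3)c(F)c2)nn(-c2cccc(C(F)(F)F)c2)c1=O` gives 460 nM; compound 3 `Cn1c(=O)c(C(=O)Nc2ccc(Oc3ccncc3-c3cccnc3)c(F)c2)nn(-c2c(Cl)cccc2Cl)c1=O` gives 720 nM.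

Compound 3 holds the second highest of these three numbers, but the steps of a 1.3-fold lower number from compound 1 to compound 3 (0.11 log units; within the scatter) and a 1.6-fold higher number from compound 2 to compound 3 (0.19 log units; within the scatter) both lie within the scatter, so the three sit close together. Compound 4 `Cn1c(=O)c(C(=O)Nc2ccc(Oc3ccncc3-c3cccnc3)c(F)c2)nn(-c2ccc(F)c(Cl)c2)c1=O` differs from compound 3 by 3-chloro-4-fluorophenyl in place of 2,6-dichlorophenyl on an aromatic nitrogen. Every measured step swaps this same aryl group, and only a 2.0-fold lower number from compound 1 to compound 2 (0.31 log units; beyond the scatter) reached beyond the scatter, a modest change. For compound 4 the expected step in this assay is therefore a 1.1-fold lower number from compound 3 to compound 4 (0.04 log units; within the scatter), likely within the scatter. Compound 4 is estimated at 650 nM, within 300 nM to 1400 nM.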

Compound 4, half-maximal inhibitory concentration: 12500 nM
Beside the measured number, compound 4's estimate is 19-fold (1.28 log units) below it; the whole stated range lies below it.
By their numbers in this assay, from the lowest: compounds 2, 3 and 1 (each within the scatter of the next, the first and the last beyond it); then compound 4.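

In this assay, going by these compounds alone, the aryl group on this nitrogen can matter far more than the earlier compounds showed: there is a 17-fold higher number from compound 3 to compound 4 (1.24 log units; beyond the scatter) and a 27-fold higher number from compound 2 to compound 4 (1.43 log units; beyond the scatter) and also a 13-fold higher number from compound 1 to compound 4 (1.13 log units; beyond the scatter) for the same kind of swap. The 3-chloro-4-fluorophenyl group carries a chlorine as the groups of compound 1 and compound 3 do, so having a chlorine on this ring does not by itself keep the number low. Nothing available explains this jump.

On these data alone, whether the fluorine or the pairing of the two halogens matters remains open. How an unsubstituted phenyl, or a phenyl carrying a methoxy group or an amine, would behave here is also unknown.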